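Octyl in place of 4-acetylphenyl on an aromatic nitrogen

A few compounds are considered here, and "the series" means these few. Any claim that something is new, unique, unknown or untested is made for them only; others in the source may bear on it.

Compound 1 `CC(=O)c1ccc(-n2cc(COc3ccc(/C=C/C(=O)c4cc5c(cc4O)OC(C)(C)CC5)cc3)nn2)cc1` has no single number to its name: in a functional assay on HepG2 cells (Homo sapiens) for antiproliferative activity, read by MTT assay (on this read-out higher numbers stand for weaker inhibition and lower numbers for stronger inhibition), compound 1 is reported as "not active" (no number reported). Two relatives do give numbers in this assay, with compound 2 `CC1(C)CCc2c(ccc(C(=O)/C=C/c3ccc(OCc4cn(-c5ccc(Cl)cc5)nn4)cc3)c2O)O1` at 102000 nM and compound 3 `CC1(C)CCc2c(ccc(C(=O)/C=C/c3ccc(OCc4cn(-c5ccc(Br)cc5)nn4)cc3)c2O)O1` at 136000 nM. Their core is not quite that of compound 1, as the structures show, so they serve only as a loose guide.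

Compound 4 `CCCCCCCCn1cc(COc2ccc(/C=C/C(=O)c3cc4c(cc3O)OC(C)(C)CC4)cc2)nn1` keeps the core of compound 1 and differs from it by octyl in place of 4-acetylphenyl on an aromatic nitrogen. A ring-bearing group thus gives way to a chain with no ring.

Among the compounds with values here, only one measured step bears on this even indirectly. The step of a 1.3-fold higher number from compound 2 to compound 3 (0.12 log units; within the scatter) lies within the scatter, but bromo in place of chloro is a far smaller change than this one, so it does not set the size of the new step. With no number for compound 1, neither a size nor a direction can be derived from it. The expectation rests instead on the level shared by compound 2 at 102000 nM and compound 3 at 136000 nM, with a real chance that no number is obtained. Compound 4 is expected at about 70000 nM, within an estimated range of 15000 nM to 250000 nM.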

Compound 4, half-maximal inhibitory concentration: 127000 nM
Compound 4: the middle estimate sits 1.8-fold (0.26 log units) below what was measured; measured number inside the range.
By their numbers in this assay, from the lowest: compounds 2, 4 and 3 (each within the scatter of the next).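

In this assay, within the data shown here, compound 1 gives "not active" (no number reported) and so no step from it to compound 4 can be read. No measured evidence at hand accounts for the result. The compounds shown leave open whether octyl and 4-acetylphenyl on the aromatic nitrogen differ in their effect on the shared core.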